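The compounds below may be only part of what the source reports. "The series", "measured", "known", "first", "only" and "open" are said of these compounds alone.

The measured compounds in a functional assay on HL-60 cells (Homo sapiens) for antiproliferative activity, read by XTT assay, with a stated time of 72 h (on this read-out lower numbers stand for stronger inhibition and higher numbers for weaker inhibition), are these:

Compound 1, `C#Cc1cn([C@@H]2O[C@H](CO)[C@@H](O)[C@H]2O)c2ncnc(N(C)C)c12`, gives 290 nM.
Compound 2, `Cc1nc(N)c2c(-c3ccccc3)cn([C@@H]3O[C@H](CO)[C@@H](O)[C@H]3O)c2n1`, reaches only a limit of the assay, > 20000 nM.
Compound 3, `Nc1nc(N)c2c(-c3ccccc3)cn([C@@H]3O[C@H](CO)[C@@H](O)[C@H]3O)c2n1`, likewise reaches only a limit of the assay, > 15000 nM.

Compound 2 therefore stands at a limit in this assay, with no number of its own; one further value shown is also a limit. Going by the values given here, the only step among measured compounds that differ in one place, a step that the two limits leave unreadable from compound 2 to compound 3, runs between two limits and its size cannot be read, as the limit of > 20000 nM in this assay, at which 1 of the 3 values shown sits, and the limit of > 15000 nM in this assay, at which 1 of the 3 values shown sits, both show. Compound 4, `Cc1nc(N)c2c(-c3ccsc3)cn([C@@H]3O[C@H](CO)[C@@H](O)[C@H]3O)c2n1`, differs from compound 2 by thiophen-3-yl in place of phenyl on an aromatic carbon. No measured step touches this change, so nothing among the shown compounds tells which way it should move this assay. Among the compounds with values here, the only compound with a number, compound 1, carries different groups at two places and gives no single-place comparison. The expectation for compound 4 is therefore that it stays near the limit of compound 2, and the step of a number no higher from compound 2 to compound 4 (the limit leaves the size open) is estimated as none beyond the scatter. Compound 4 is expected to give about 20000 nM, within 5000 nM to 80000 nM, most likely again as a limit.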

Compound 4, half-maximal inhibitory concentration: > 20000 nM
Compound 4 was reported as a limit; the forecaster's own chance of this, stated with the estimate: 70%; the middle value lies on the limit itself.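

Compound 2 and compound 4 both stand at a limit in this assay, with no number of their own, so the step between them cannot be read: the limit of > 20000 nM in this assay, at which 2 of the 4 values shown sit.

The compounds shown leave open whether thiophen-3-yl in place of phenyl on this aromatic carbon shifts this assay at all, and in which direction.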